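The source may report more compounds than this note shows. Statements on the series, on what has been measured and on what is new or still open speak of the compounds shown alone.

Of the compounds shown here, three built on one shared core have been tested in a functional assay on CCRF-CEM cells (Homo sapiens) for cytotoxicity, read by sulforhodamine B assay, with a stated time of 48 h; a higher number here means a weaker inhibitor of growth, a lower number a stronger inhibitor of growth. Compound 1 `Nc1nc(Cl)c2ncn(Cc3ccccc3CCl)c2n1` reaches only a limit of the assay, > 100000 nM. Compound 2 `ClCc1cccc(Cn2cnc3nc(Cl)nc(Cl)c32)c1` gives 2750 nM. Compound 3 `ClCc1ccccc1Cn1cnc2c(Cl)nc(Cl)nc21` gives 90 nM, the lowest of the two real numbers, and the nearest number, that of compound 2, lies well beyond the scatter above it.

For the measured compounds named here, only one change of a single group has been measured so far: an at least 1100-fold lower number from compound 1 to compound 3 (3.04 log units; beyond the scatter). Its true size is not known, because compound 1 sits at the limit of > 100000 nM in this assay, at which 1 of the 3 values shown sits. It does show that the group on this aromatic carbon matters greatly for growth inhibition.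

Compound 4 `ClCc1ccccc1Cn1cnc2c(Cl)ncnc21` is the next compound, and it alters the same aromatic carbon: hydrogen in place of chloro on an aromatic carbon. The measured step from compound 1 to compound 3 bears on this change, since it too swapped the group at this carbon, with a large effect. Removing the chloro that compound 3 carries there is therefore expected to move the number upward in this assay, though by how much is uncertain, since hydrogen is neither of the two groups already compared. The expected step is a 17-fold higher number from compound 3 to compound 4 (1.22 log units; beyond the scatter). Compound 4 is estimated to give 1500 nM, within a range from 200 nM to 15000 nM.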

Compound 4, concentration for total growth inhibition: 3230 nM
Beside the measured number, compound 4's estimate is 2.2-fold (0.33 log units) below it; measured number inside the range.
By their numbers in this assay, from the lowest: compound 3; then compounds 2 and 4 (each within the scatter of the next). At a limit, above all of these: compound 1.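

Measured against hydrogen, the two groups on this carbon between two ring nitrogen atoms pull in opposite directions. Putting hydrogen in place of chloro gives a 36-fold higher number from compound 3 to compound 4 (1.55 log units; beyond the scatter) in this assay, so the chloro of compound 3 itself goes with stronger growth inhibition, and the earlier comparison of chloro with amino could not separate its share from that of the amino group. Putting hydrogen in place of amino gives an at least 30-fold lower number from compound 1 to compound 4 (1.49 log units; beyond the scatter), so the amino group goes with weaker growth inhibition than no group at all, but the full size of this step cannot be known because compound 1 stands at a limit and not at a number: the limit of > 100000 nM in this assay, at which 1 of the 4 values shown sits.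

The three compounds that differ at this carbon place chloro lowest, then hydrogen, then amino, but they leave open whether a bromo or a methoxy group there would match or pass the chloro of compound 3. They also leave open what a methoxy group would do in place of the chloro group that lies meta to this carbon and is kept in compound 3 and compound 4.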